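The source may report more compounds than this note shows. Statements on the series, on what has been measured and on what is new or still open speak of the compounds shown alone.

Within the data shown here, compound 3, with the structure `Cc1cc(-c2ccco2)cc(C)c1Nc1ccnc(Nc2ccc(C#N)cc2)n1`, is one of three compounds measured in a toxicity assay on MT4 cells (Homo sapiens) for cytotoxicity, read by MTT assay, with a stated time of 5 days (a higher number here means that more compound is tolerated, a lower number that less compound is tolerated), in which compound 3 gives 1700 nM. Among these three numbers it stands second highest: its nearest neighbour is compound 1, with the structure `Cc1cnc(Nc2ccc(C#N)cc2)nc1Nc1c(F)cc(-c2cncnc2)cc1F`, which in this assay gives 900 nM, a gap that lies within the scatter; the furthest is compound 2, with the structure `Cc1cnc(Nc2ccc(C#N)cc2)nc1Nc1c(F)cc(-c2cccs2)cc1F`, which in this assay gives 8000 nM, a gap beyond the scatter.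

Compound 4, with the structure `Cc1ccc(-c2cc(C)c(Nc3ccnc(Nc4ccc(C#N)cc4)n3)c(C)c2)s1`, has not yet been measured. It differs from compound 3 in one place: 5-methylthiophen-2-yl in place of furan-2-yl on an aromatic carbon.

Among the measured compounds shown here, only one measured step bears on this change, and only loosely: an 8.9-fold higher number from compound 1 to compound 2 (0.95 log units; beyond the scatter), a swap of a six-membered heteroaryl for a thiophene on a different core. The present change swaps one five-membered heteroaryl for another, so a smaller effect is expected. Compound 4 is therefore expected to give a modestly higher number, a 1.8-fold higher number from compound 3 to compound 4 (0.25 log units; within the scatter), leading to an estimate of 3000 nM, with a range from 1200 nM to 9000 nM.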

Compound 4, half-maximal cytotoxic concentration: 28000 nM
Beside the measured number, compound 4's estimate is 9.3-fold (0.97 log units) below it, and the stated range ends below it.
By their numbers in this assay, from the lowest: compounds 1 and 3 (each within the scatter of the next); then compound 2; then compound 4.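

At the position para to a large group and meta to two methyl groups, 5-methylthiophen-2-yl in place of furan-2-yl gives a 16-fold higher number from compound 3 to compound 4 (1.22 log units; beyond the scatter) in this assay. Among these compounds, the only earlier step, an 8.9-fold higher number from compound 1 to compound 2 (0.95 log units; beyond the scatter), replaced pyrimidin-5-yl on the core of compound 1, whereas this one shows a step beyond the scatter on the core of compound 3, between two five-membered aromatic rings with the same counts of hydrogen-bond donors and acceptors. Nothing available explains this step. The change alters the ring hetero atom from oxygen to sulfur and adds a methyl group together, so the compounds shown do not separate the two. As far as these compounds go, how 5-methylfuran-2-yl, or a ring bearing an amine or a carboxylic acid, would fare at this position remains open.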